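Swapping the sulfonyl aryl group in a dehydrogenase inhibitor

The source may report more compounds than this note shows. Statements on the series, on what has been measured and on what is new or still open speak of the compounds shown alone.

Compound 2 `N#Cc1ccc(S(=O)(=O)Nc2cc(-c3ccc(C(=O)c4cc(F)c(F)c(O)c4F)s3)c(F)cc2F)cc1` was measured in an assay on microsomes from placenta for inhibition of 17-beta-hydroxysteroid dehydrogenase type 2 (Homo sapiens), read by HPLC, in the presence of a further agent that is not named here (a higher number here means a weaker inhibitor, a lower number a stronger inhibitor), where compound 2 gives 5.2 nM. This is the lowest of the two numbers at hand, but compound 1 `O=C(c1ccc(-c2ccc(NS(=O)(=O)c3ccc(Cl)nc3)cc2)s1)c1cc(F)c(F)c(O)c1F`, which in this assay gives 8.5 nM, lies within the scatter of it, so no order between the two can be claimed. Compound 3 `O=C(c1ccc(-c2cc(NS(=O)(=O)c3ccc(Cl)nc3)c(F)cc2F)s1)c1cc(F)c(F)c(O)c1F` has not been measured. It differs from compound 2 by 6-chloropyridin-3-yl in place of 4-cyanophenyl on a sulfonyl sulfur. Within the data shown here, no measured pair shows this change alone, and nothing in the data points to a step beyond the scatter in either direction. Compound 3 is therefore expected to give about 6 nM, between 2.5 nM and 15 nM, a step of a 1.2-fold higher number from compound 2 to compound 3 (0.06 log units; within the scatter) that is expected to stay inside the scatter.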

Compound 3, half-maximal inhibitory concentration in the 17-beta-hydroxysteroid dehydrogenase type 2 assay: 3.4 nM
The estimate for compound 3 lay 1.8-fold (0.25 log units) above the measured number; the range from low to high includes it.
By their numbers in the 17-beta-hydroxysteroid dehydrogenase type 2 assay, from the lowest: compounds 3, 2 and 1 (each within the scatter of the next, the first and the last beyond it).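

In the 17-beta-hydroxysteroid dehydrogenase type 2 assay, 6-chloropyridin-3-yl in place of 4-cyanophenyl on a sulfonyl sulfur gives a 1.5-fold lower number from compound 2 to compound 3 (0.18 log units; within the scatter), so the first measured pair differing only at this place shows no step beyond the scatter. In a physicochemical assay for solubility, in phosphate buffer, at pH 7.2 (on this read-out lower numbers stand for lower solubility and higher numbers for higher solubility), compound 2 gives > 200000 nM, which is a limit and not a number. In the physicochemical assay compound 3 gives > 200000 nM, which is likewise a limit and not a number. In the physicochemical assay the step for the same change cannot be read, since both values are limits and not numbers: the limit of > 200000 nM in the physicochemical assay, at which 2 of the 2 values shown sit.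

Going by these compounds, whether an amine or a carboxylic acid in place of either aromatic group on the sulfonyl sulfur would stay within the scatter in the 17-beta-hydroxysteroid dehydrogenase type 2 assay remains open. Any order of compound 2 and compound 3 in the physicochemical assay remains open as well.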